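A methyl group added across two different cores

A few compounds are considered here, and "the series" means these few. Any claim that something is new, unique, unknown or untested is made for them only; others in the source may bear on it.

Compound 1, `C/C(=C\c1cc(-c2cccnc2)co1)C(N)=O`, in a functional assay on HeLa cells (Homo sapiens) for cytotoxicity, read by CCK-8 assay, with a stated time of 24 h (a lower number here means a stronger inhibitor, a higher number a weaker inhibitor), gives > 50000 nM, which is a limit of the assay rather than a number.
Compound 2, `C/C(=C\c1cc(-c2ccc(C)nc2)co1)C(N)=O`, in this assay gives > 50000 nM, again a limit of the assay.
Compound 3, `C/C(=C\c1cccc(-c2ccccc2)c1)C(N)=O`, in this assay gives 15700 nM.

Compound 1 and compound 2 share one core and differ by methyl in place of hydrogen on an aromatic carbon, a step that reads as a step that the two limits leave unreadable from compound 1 to compound 2; both sit at the limit of > 50000 nM in this assay, at which 2 of the 3 values shown sit, so its size cannot be read. Compound 3 has a different core, and the difference between the two cores is not broken down here. Compound 4, `C/C(=C\c1cccc(-c2ccc(C)cc2)c1)C(N)=O`, has not yet been measured; it differs from compound 3 by methyl in place of hydrogen on an aromatic carbon. This is the same kind of change as that from compound 1 to compound 2, but not the same: there the methyl enters on a six-membered aromatic ring with 1 nitrogen, next to the ring nitrogen, here on a six-membered aromatic ring of carbon only. With the earlier step unreadable, the expectation rests only on compound 3 at 15700 nM and on the methyl that enters, so a step of a 1.3-fold lower number from compound 3 to compound 4 (0.12 log units; within the scatter) is expected. Compound 4 is therefore estimated at 12000 nM, between 5000 nM and 35000 nM.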

Compound 4, half-maximal inhibitory concentration: 24800 nM
Estimate against measurement, compound 4: 2.1-fold (0.32 log units) below; the range from low to high includes it.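

In this assay the added methyl group gives a 1.6-fold higher number from compound 3 to compound 4 (0.20 log units; within the scatter) and so leaves no readable difference on the core of compound 3. On the core of compound 1 the same kind of change cannot be read, as compound 1 and compound 2 both stand at a limit of the assay and not at a number: the limit of > 50000 nM in this assay, at which 2 of the 4 values shown sit. The result therefore does not show whether the change carries from one core to the other, and the comparison is further limited by the methyl entering on a six-membered aromatic ring with a nitrogen in one case and on a ring of carbon only in the other.

The compounds shown leave open whether a different group at the same place on the ring of carbon only, such as an amine, a carboxylic acid or a longer chain, would shift the value of compound 3 beyond the scatter. They also leave open whether any such group would bring the core of compound 1 to a readable number.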